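Trimming the polyamine tail of a trimethoxyphenyl chalcone

The compounds below may be only part of what the source reports. "The series", "measured", "known", "first", "only" and "open" are said of these compounds alone.

Compound 1 `COc1cc(C(=O)/C=C/c2ccc(OCCCC(=O)NCCCCN(CCCN)CCCCN)cc2)cc(OC)c1OC` carries a branched polyamine tail on its amide. For the measured compounds named here, in a functional assay on PC-3 cells (Homo sapiens) for antiproliferative activity, read by MTT assay, with a stated time of 48 h (a lower number here means a stronger inhibitor, a higher number a weaker inhibitor), compound 1 gives 55400 nM, the highest of the two numbers known, while compound 2 `COc1ccc(/C=C/C(=O)c2cc(OC)c(OC)c(OC)c2)cc1OCCCC(=O)NCCCNCCCCNCCN` gives 31800 nM, a gap that sits within the scatter. Compound 3 `COc1cc(C(=O)/C=C/c2ccc(OCCCC(=O)NCCCNCCCCN)cc2)cc(OC)c1OC` differs from compound 1 by (4-aminobutyl)amino in place of ((4-aminobutyl)(3-aminopropyl)amino)methyl on a saturated chain carbon, three bonds along the chain from an amide-type nitrogen. Going by the values given here, no measured pair covers this change, so the expectation rests on compound 1 alone: the step from compound 1 to compound 3 is expected to be small, a 1.3-fold higher number from compound 1 to compound 3 (0.10 log units; within the scatter), toward a somewhat higher number if anything. Compound 3 is therefore expected to give 70000 nM, between 25000 nM and 200000 nM.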

Compound 3, half-maximal inhibitory concentration: > 100000 nM
Compound 3 was reported as a limit (the forecaster's own chance of this, stated with the estimate: 15%); middle value at least 1.4-fold (0.15 log units) away from the limit.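

In this assay, placing (4-aminobutyl)amino where ((4-aminobutyl)(3-aminopropyl)amino)methyl stood on this saturated chain carbon gives an at least 1.8-fold higher number from compound 1 to compound 3 (0.25 log units; that floor lies within the scatter). The smaller group thus brings no lower number at this position, although the floor of the step does not separate the two compounds. The reading for compound 3 is a limit and not a number: the limit of > 100000 nM in this assay, at which 1 of the 3 values shown sits.

As far as these compounds go, how far compound 3 really lies from compound 1 stays open. Also open, from the compounds shown here alone, is whether a longer chain or a hydroxyl group in place of (4-aminobutyl)amino at this position would move the number.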